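Swapping One Ring on Compound 2

The source may hold more compounds than are shown below. What is called first, only, known or untested is meant among the compounds shown, and "the series" means these compounds.

In a functional assay on VCaP cells (Homo sapiens) for antiproliferative activity, read by CCK-8 assay, with a stated time of 6 days (a lower number here means a stronger inhibitor, a higher number a weaker inhibitor), compound 1 (`N#Cc1ccc(N2CCCc3c(-c4ccncc4)cccc32)cc1C(F)(F)F`) gives > 30000 nM which is a limit of the assay and not a number. Compound 3 (`CCN(c1cccc(-n2ccnc2)c1)c1ccc(C#N)c(C(F)(F)F)c1`) carries 1H-imidazol-1-yl and gives > 30000 nM which is also a limit. Compound 2 (`CCN(c1ccc(C#N)c(Cl)c1)c1cc(-c2cncnc2)ccc1C`) gives 3920 nM as the only true number among these three. Compound 4 (`CCN(c1ccc(C#N)c(Cl)c1)c1cc(-n2ccnc2)ccc1C`) is compound 2 with 1H-imidazol-1-yl in place of pyrimidin-5-yl on an aromatic carbon. Going by the values given here, no measured pair shows this swap, so its size is uncertain. A moderate loss of potency in this assay is expected, with an estimated step (a 1.5-fold higher number from compound 2 to compound 4 (0.18 log units; within the scatter)) towards weaker inhibition. For compound 4 the estimated value is 6000 nM with an expected range from 1500 nM to 24000 nM in repeat measurements.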

Compound 4, half-maximal inhibitory concentration: > 30000 nM
Compound 4 gave a limit, no number; the forecaster's own chance of this, stated with the estimate: 15%; middle value at least 5.0-fold (0.69 log units) from the limit.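

Going by these compounds alone, this is the first comparison here in which only one place differs. In this assay, putting 1H-imidazol-1-yl in place of pyrimidin-5-yl on this aromatic carbon, para to a methyl group, clearly weakens activity (an at least 7.6-fold higher number from compound 2 to compound 4 (0.88 log units; beyond the scatter)), so activity at this position depends on which ring is attached. Compound 4 gave a limit and not a number, so the step shows only a minimum size: the limit of > 30000 nM in this assay, at which 3 of the 4 values shown sit.

On these data alone, it remains open whether a group other than a ring at this carbon, such as an amine or a carboxylic acid, would keep the activity of compound 2.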